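A few compounds are considered here, and "the series" means these few. Any claim that something is new, unique, unknown or untested is made for them only; others in the source may bear on it.

Measured so far in a functional assay on the whole organism for inhibition, with Rattus norvegicus as the target, at a dose of 3 mg/kg by the intraperitoneal route; a higher number here means more inhibition at the dose given (going by the name of the read-out), a lower number less inhibition:
compound 3 `Cn1cnc2nc(-c3ccc(Cl)cc3)nn2c1=S`: 90%
compound 2 `C/N=C(\S)n1nc(/C=C/c2ccc(Cl)cc2)nc1N`: 25%
compound 1 `C/N=C(\S)n1nc(-c2ccco2)nc1N`: 18%

Compound 3 stands highest of the three numbers in this assay. The nearest is compound 2, whose inhibition lies far below that of compound 3, beyond the scatter; the furthest is compound 1, lower still, also beyond the scatter. Compound 4 `Cn1cnc2nc(-c3ccc(Br)cc3)nn2c1=S` is the next compound to be measured. It differs from compound 3 in one place: bromo in place of chloro on an aromatic carbon. Among the compounds with values here, no pair among the measured compounds isolates such a change, so no measured step sets the size. The change from compound 3 to compound 4 is expected to give a step of a number 5 percentage points lower from compound 3 to compound 4 (within the scatter), none beyond the scatter. Compound 4 is therefore estimated at 85%, within 65% to 97%.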

Compound 4, a percentage reported as inhibition, in the whole organism at one dose (the size of the read-out at that dose, not a potency): 84%
Beside the measured number, compound 4's estimate is 1 percentage points above it; the measured number falls inside the stated range.
By their numbers in this assay, from the lowest: compounds 1 and 2 (each within the scatter of the next); then compounds 4 and 3 (each within the scatter of the next).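

In this assay, within the data shown here, bromo in place of chloro on an aromatic carbon, para to a large group, gives a number 6 percentage points lower from compound 3 to compound 4 (within the scatter) and is the first single change that can be read. At this position, chloro and bromo cannot be told apart, so the high inhibition of compound 3 does not depend on chloro alone. Nothing shown explains this outcome.

From the compounds shown here alone, whether the inhibition would survive an amine, a methoxy group or a carboxylic acid at this place remains open. So does the effect of replacing the methyl on the core.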